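Removing the propyl from the indole nitrogen of compound 1

This account rests on a few compounds, and the source may have more. Where it says the series, first, only, none or still open, it means among the compounds named here.

Compound 1 `CCCn1c(-c2ccc(O)cc2)c(C)c2cc(O)ccc21` gives 2300 nM in a functional assay on A2780 cells (Homo sapiens) for inhibition, read by trypan blue exclusion, with a stated time of 72 h; a higher number here means a weaker inhibitor of growth, a lower number a stronger inhibitor of growth; compound 2 `Cc1c(-c2ccc(O)cc2)n(CCCOc2ccccc2)c2ccc(O)cc12` gives 2200 nM and stands within the scatter of compound 1, as the step of a 1.0-fold lower number from compound 1 to compound 2 (0.02 log units; within the scatter) shows. Compound 3 `Cc1c(-c2ccc(O)cc2)[nH]c2ccc(O)cc12` differs from compound 1 by hydrogen in place of propyl on an aromatic nitrogen. Among the compounds with values here, no measured step touches the group on the aromatic nitrogen; the one measured step, on the chain carbon, was within the scatter and gives no lead for this change. Without such a precedent, compound 3 is expected to stay close to compound 1, with a 1.1-fold higher number from compound 1 to compound 3 (0.05 log units; within the scatter) as the working expectation and a wide range. Compound 3 is therefore estimated at 2600 nM, between 800 nM and 8000 nM.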

Compound 3, concentration for 50% growth inhibition: 11000 nM
For compound 3 the middle estimate is 4.2-fold (0.63 log units) below the measured one; the whole stated range lies below it.
By their numbers in this assay, from the lowest: compounds 2 and 1 (each within the scatter of the next); then compound 3.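

In this assay the aromatic nitrogen is not indifferent to substitution: hydrogen in place of propyl gives a 4.8-fold higher number from compound 1 to compound 3 (0.68 log units; beyond the scatter) and so weakens growth inhibition beyond the scatter. The earlier step, a 1.0-fold lower number from compound 1 to compound 2 (0.02 log units; within the scatter), showed only that phenoxy on the chain changes nothing measurable once the chain is present; this result shows that the chain itself counts. No evidence at hand accounts for this step.

As far as these compounds go, whether a methyl or ethyl on this nitrogen is enough to match compound 1 remains open. So does the effect of an amine or a carboxylic acid at the end of the chain.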